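From furan-3-yl to ethynyl on the shared core

A few compounds are considered here, and "the series" means these few. Any claim that something is new, unique, unknown or untested is made for them only; others in the source may bear on it.

Measured so far in a functional assay on HL-60 cells (Homo sapiens) for antiproliferative activity, read by XTT assay, with a stated time of 72 h; on this read-out lower numbers stand for stronger inhibition and higher numbers for weaker inhibition:
Compound 1 `CNc1ncnc2c1c(-c1cccs1)cn2[C@@H]1O[C@H](CO)[C@@H](O)[C@H]1O`: > 20000 nM (a limit)
Compound 2 `COc1nc(N)nc2c1c(-c1ccoc1)cn2[C@@H]1O[C@H](CO)[C@@H](O)[C@H]1O`: > 20000 nM (a limit)

Compound 2 gives no number in this assay, only the limit > 20000 nM. Compound 1 likewise reaches only a limit, > 20000 nM. Taken together, the data so far amount to the limit of > 20000 nM in this assay, at which 2 of the 2 values shown sit.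

Compound 3 `C#Cc1cn([C@@H]2O[C@H](CO)[C@@H](O)[C@H]2O)c2nc(N)nc(OC)c12` carries ethynyl in place of furan-3-yl on an aromatic carbon. Within the data shown here, no measured pair shows what this change does, so any forecast is uncertain, and compound 3 may also end up reported only as a limit. If a number appears, a clear move towards stronger inhibition, beyond the usual scatter, is expected. The estimated change is an at least 4.0-fold lower number from compound 2 to compound 3 (0.60 log units; beyond the scatter). For compound 3 the expected value is 5000 nM, with an estimated range of 300 nM to 20000 nM.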

Compound 3, half-maximal inhibitory concentration: > 20000 nM
Compound 3: only a limit was reported; the forecaster's own chance of this, stated with the estimate: 45%; middle value at least 4.0-fold (0.60 log units) away from the limit.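

Compound 3 also gives only a limit in this assay, > 20000 nM. No step can be read between compound 2 and compound 3, and the series so far stands at one point: the limit of > 20000 nM in this assay, at which 3 of the 3 values shown sit.

The compounds shown leave open whether furan-3-yl and ethynyl differ at all on the shared core.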